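From hydroxy to acetoxy: one small change, one open number

The source may hold more compounds than are shown below. What is called first, only, known or untested is meant among the compounds shown, and "the series" means these compounds.

Three compounds have been examined so far in a functional assay on MCF7 cells (Homo sapiens) for cytotoxicity, read by MTT assay, with a stated time of 24 h (on this read-out lower numbers stand for stronger inhibition and higher numbers for weaker inhibition), and two of them gave a number. Compound 1 `CCOC(=O)/C=C/c1cc(OC)c(O)c(OC)c1/C(=C/c1cc(OC)c(O)c(OC)c1)C(=O)OCC` gives 74000 nM there, and compound 2 `CCOC(=O)/C=C/c1ccc(O)c(/C(=C/c2ccc(O)cc2)C(=O)OCC)c1` gives 12000 nM as the lower of the two numbers, a gap from compound 1 that lies beyond the usual scatter of repeated measurements. The entry for compound 3 `CCOC(=O)C(=C\c1ccc(OC)c(OC)c1)/C(=C/c1ccc(OC)c(OC)c1)C(=O)OCC` reads "not determined" (no result reported) and so it offers no comparison.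

The next compound is compound 4 `CCOC(=O)/C=C/c1ccc(O)c(/C(=C/c2ccc(OC(C)=O)cc2)C(=O)OCC)c1`, which differs from compound 2 in one place. The change is acetyl in place of hydrogen on an oxygen on an aromatic ring and it amounts to acetyl in place of hydrogen on an oxygen on an aromatic ring, so that a 4-hydroxyphenyl becomes a 4-acetoxyphenyl.

Among the measured compounds shown here, no pair of measured compounds shows this change alone, so the data give no direct measure of its size. Compound 1 and compound 2 differ in more than one place, and their gap cannot be carried over. The expected no change at the digits printed from compound 2 to compound 4 (within the scatter) is therefore none beyond the scatter, with neither direction favoured. In this assay compound 4 is estimated at 12000 nM with an expected range from 4500 nM to 32000 nM around that middle.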

Compound 4, half-maximal inhibitory concentration: 66000 nM
Beside the measured number, compound 4's estimate is 5.5-fold (0.74 log units) below it; the measured number lies above the stated range.
By their numbers in this assay, from the lowest: compound 2; then compounds 4 and 1 (each within the scatter of the next).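

In this assay, this oxygen on the aromatic ring proves sensitive to change: acetyl in place of hydrogen gives a 5.5-fold higher number from compound 2 to compound 4 (0.74 log units; beyond the scatter). Among the compounds shown here, until now no two measured compounds differed in one place, so this is the first size and direction attached to a single change, and the direction is towards weaker inhibition. Nothing among the available data explains why the number rises when the 4-hydroxyphenyl becomes a 4-acetoxyphenyl.

This single step cannot separate the loss of the hydrogen from the arrival of the acetyl, and an amino group in place of the hydroxy, or a longer acyl chain such as butanoyl on the same oxygen, would help to tell those two readings apart. From the compounds shown here alone, it also remains open whether the same acetyl on the other hydroxy of compound 2 would give a step of similar size, or whether this result belongs to this one place alone.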